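Amide to Amino-Carbonyl: An Estimate for Compound 3

The source may report more compounds than this note shows. Statements on the series, on what has been measured and on what is new or still open speak of the compounds shown alone.

Compound 1 `O=C(Nc1cccc(-n2cc(-c3ccncc3)c(-c3ccc(Cl)c(O)c3)n2)c1)Nc1cccc(C(F)(F)F)c1`: > 32500 nM
Compound 2 `COc1cc(-c2nn(-c3cccc(NC(=O)c4cccc(C(F)(F)F)c4)c3)cc2-c2ccncc2)ccc1Cl`: > 50000 nM

In a functional assay on NCI-H322M cells (Homo sapiens) for inhibition, read by sulforhodamine B assay, with a stated time of 48 h (a lower number here means that less compound is tolerated, a higher number that more compound is tolerated), compound 1 gives > 32500 nM, which is a limit of the measurement and not a number (the limit of > 32500 nM in this assay, at which 1 of the 2 values shown sits). Compound 2 likewise gives only a limit, > 50000 nM (the limit of > 50000 nM in this assay, at which 1 of the 2 values shown sits). Within the data shown here, compound 2 thus stands at a limit, as does the one further value shown, and no order between the two can be drawn.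

Compound 3 `COc1cc(-c2nn(-c3cccc(NC(=O)Nc4cccc(C(F)(F)F)c4)c3)cc2-c2ccncc2)ccc1Cl` differs from compound 2 by (3-(trifluoromethyl)phenyl)amino in place of 3-(trifluoromethyl)phenyl on a carbonyl carbon. No measured step of this kind exists among these compounds. Compound 1 already carries the (3-(trifluoromethyl)phenyl)amino group on a carbonyl carbon and sits at a limit, > 32500 nM. The step that the limit leaves unreadable from compound 2 to compound 3 is therefore expected to be none beyond the scatter. Compound 3 is estimated at 60000 nM, in the range 20000 nM to 200000 nM, and most probably reported again only as a limit.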

Compound 3, concentration lethal to 50% of the cells: > 50000 nM
Compound 3 gave a limit, no number; the forecaster's own chance of this, stated with the estimate: 80%; the middle value is on the limit's open side.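

In this assay, among these compounds, compound 1, compound 2 and compound 3 all give only limits, and no step between them can be read. The compounds shown leave open whether (3-(trifluoromethyl)phenyl)amino in place of 3-(trifluoromethyl)phenyl, or methyl in place of hydrogen on the oxygen, changes the value at all.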